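The source may report more compounds than this note shows. Statements on the series, on what has been measured and on what is new or still open speak of the compounds shown alone.

Measured in a functional assay on J774 cells (Mus musculus) for cytotoxicity, with a stated time of 48 h; a higher number here means a weaker inhibitor, a lower number a stronger inhibitor:
- compound 1 `CC(C)(C)OC(=O)NCC(=O)N1CCC[C@H]1C(=O)N1[C@H](C(=O)OCc2ccccc2)[C@H]1C(=O)OCc1ccccc1`: > 100000 nM
- compound 2 `CC(C)C[C@H](NC(=O)OC(C)(C)C)C(=O)N1CCC[C@@H]1C(=O)N1[C@H](C(=O)OCc2ccccc2)[C@H]1C(=O)OCc1ccccc1`: > 100000 nM

Compound 2 stands at > 100000 nM, which is a limit of the assay and not a number. Compound 1 gives no firmer reading, since its > 100000 nM is also a limit. For the measured compounds named here, the series so far therefore rests on (the limit of > 100000 nM in this assay, at which 2 of the 2 values shown sit).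

Compound 3 `CC(C)C[C@H](NC(=O)OC(C)(C)C)C(=O)N1CCC[C@H]1C(=O)N1[C@H](C(=O)OCc2ccccc2)[C@H]1C(=O)OCc1ccccc1` is the next to be tested in this assay. It is closely related to compound 2: the two compounds have the same atoms and bonds and differ only in configuration as drawn: 1 of 4 stereo elements differ; a stereocentre at a saturated ring carbon is drawn R in compound 2 and S in compound 3. Going by the values given here, no measured step is available to size such a change. Since neither measured compound gives a number, no shift beyond the scatter is expected in either direction, and compound 3 will most likely report the same limit. The expected step is a number no higher from compound 2 to compound 3 (the limit leaves the size open). For compound 3 the estimated value is 100000 nM, with an expected range from 40000 nM to 200000 nM.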

Compound 3, half-maximal inhibitory concentration: > 125000 nM
Compound 3: no number, only a limit; the forecaster's own chance of this, stated with the estimate: 85%; at least 1.2-fold (0.09 log units) between middle value and limit.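

In this assay compound 3 gives > 125000 nM, which is a limit of the assay and not a number. For the compounds shown here, with compound 1 and compound 2 also at limits, no step to compound 3 can be read. The compounds shown leave open whether the drawn configuration or the isobutyl group shifts the half-maximal inhibitory concentration at all.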